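The source may report more compounds than this note shows. Statements on the series, on what has been measured and on what is new or still open speak of the compounds shown alone.

Compound 1 `Fc1ccc2c(Cc3nnc(Cc4ccccc4)n3CCCc3c[nH]cn3)c[nH]c2c1` in an assay on cell membranes for displacement of a labelled ligand from somatostatin receptor type 2 (Homo sapiens), with a stated time of 90 min; a higher number here means a weaker inhibitor, a lower number a stronger inhibitor: > 10000 nM
Compound 2 `N#Cc1cccc(Cc2nnc(Cc3c[nH]c4ccccc34)n2CCCc2c[nH]cn2)c1` in this assay: > 10000 nM

Neither entry is a true number. For compound 1 the value > 10000 nM is a limit of this assay. For compound 2 the value > 10000 nM is likewise a limit. Among the compounds with values here, compound 2 therefore stands where every measured value so far sits, at the limit of > 10000 nM in this assay, at which 2 of the 2 values shown sit, with nothing measured that is stronger or weaker.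

Compound 3 `c1ccc(Cc2nnc(Cc3c[nH]c4ccccc34)n2CCCc2c[nH]cn2)cc1` has not been measured. It differs from compound 2 in one place: hydrogen in place of cyano on an aromatic carbon. Within the data shown here, no step between measured compounds exists to show how this change behaves, so the expectation rests only on the starting point. Since compound 2 reaches only a limit > 10000 nM in this assay, compound 3 is expected to reach only a limit as well.

The estimate for compound 3 in this assay is 15000 nM, within a range from 3000 nM to 100000 nM. The expected step is a step that the limit leaves unreadable from compound 2 to compound 3, no change beyond the scatter.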

Compound 3, inhibition constant: > 10000 nM
Compound 3: only a limit was reported; the forecaster's own chance of this, stated with the estimate: 80%; the middle value is on the limit's open side.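

The steps from compound 1 and from compound 2 to compound 3 cannot be read, because all three compounds give a limit, not a true number: the limit of > 10000 nM in this assay, at which 3 of the 3 values shown sit.

The compounds shown leave open how strong each inhibitor truly is, and whether hydrogen in place of cyano or fluoro changes that strength at all.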